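A few compounds are considered here, and "the series" means these few. Any claim that something is new, unique, unknown or untested is made for them only; others in the source may bear on it.

Compound 2 `CNC1=C([S+](C)[O-])C(=O)c2ncccc2C1=O` serves as the starting point of this set. In a functional assay on cells (Neutrophil, Homo sapiens) for inhibition, read by WST assay, with a stated time of 20 min (a lower number here means a stronger inhibitor, a higher number a weaker inhibitor), compound 2 gives only a limit, > 200000 nM. Compound 1 `CNC1=C(SC)C(=O)c2ncccc2C1=O` differs from compound 2 by a group of 2 heavy atoms (1 carbon, 1 sulfur; no ring) in place of a group of 3 heavy atoms (1 carbon, 1 oxygen, 1 sulfur; no ring), on a double-bonded ring carbon. In this assay compound 1 likewise returns a limit, > 200000 nM. The two limits leave the step that the two limits leave unreadable from compound 2 to compound 1 unreadable. Compound 3 `C[S+]([O-])C1=C(N)C(=O)c2cccnc2C1=O` differs from compound 2 by hydrogen in place of methyl on an amine nitrogen, and that is how the two cores differ. In this assay compound 3 also gives a limit, > 200000 nM. The step that the two limits leave unreadable from compound 2 to compound 3 is therefore unreadable as well, because every value sits at the limit of > 200000 nM in this assay, at which 3 of the 3 values shown sit.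

Compound 4 `CSC1=C(N)C(=O)c2cccnc2C1=O` has not yet been measured; it differs from compound 3 by a group of 2 heavy atoms (1 carbon, 1 sulfur; no ring) in place of a group of 3 heavy atoms (1 carbon, 1 oxygen, 1 sulfur; no ring), on a double-bonded ring carbon. This is the same kind of change as that from compound 2 to compound 1, though the place is not the same: there the group sat next to the ring atom that bears a methylamino group, here next to the ring atom that bears an amino group. Since all three measured compounds rest at the limit of > 200000 nM in this assay, at which 3 of the 3 values shown sit, the step of a number no higher from compound 3 to compound 4 (the limit leaves the size open) is expected to be unreadable in the same way. Compound 4 is thus expected to give 200000 nM in this assay, most likely as another limit.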

Compound 4, half-maximal inhibitory concentration: > 150000 nM
Compound 4 gave a limit, no number (the forecaster's own chance of this, stated with the estimate: 85%); the middle value does not contradict the limit.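

In this assay compound 4 gives only a limit, > 150000 nM. The steps linking compound 4 with compound 3 and with compound 1 therefore cannot be read. The compounds shown leave open how strongly any of them inhibits, and whether either methylsulfanyl at the double-bonded ring carbon or hydrogen in place of methyl on the amine nitrogen changes inhibition at all.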